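Removing the Fluorines from the Side Chain of Compound 3

A few compounds are considered here, and "the series" means these few. Any claim that something is new, unique, unknown or untested is made for them only; others in the source may bear on it.

Compound 1 `Cn1c(-c2ccccc2C(F)(F)F)nnc1C12CCC(CCS(C)(=O)=O)(CC1)CC2` gives in an assay on CHO-K1 cells for inhibition of 11-beta-hydroxysteroid dehydrogenase type 2 (Homo sapiens), read by scintillation proximity assay (a higher number here means a weaker inhibitor, a lower number a stronger inhibitor), a limit, > 4000 nM.
Compound 2 `CCS(=O)(=O)CCC12CCC(c3nnc(-c4ccccc4Br)n3C)(CC1)CC2` gives in this assay a limit, > 4000 nM.
Compound 3 `Cn1c(-c2ccccc2C(F)(F)F)nnc1C12CCC(CCCC(C)(F)F)(CC1)CC2` gives in this assay a limit, > 4000 nM.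

All three measured compounds sit at the limit of > 4000 nM in this assay, at which 3 of the 3 values shown sit, so compound 3 stands nowhere above that limit. Among the compounds with values here, the one step that touches it, a step that the two limits leave unreadable from compound 1 to compound 3, is unreadable because both ends are limits. Compound 4 `CCCCCC12CCC(c3nnc(-c4ccccc4C(F)(F)F)n3C)(CC1)CC2` differs from compound 3 by ethyl in place of 1,1-difluoroethyl on a saturated chain carbon, three bonds along the chain from a saturated ring carbon. Within the data shown here, no measured step speaks to this change, and the only comparable step stays hidden by the limits. Compound 4 is therefore expected to remain at the limit as well, with a step that the limit leaves unreadable from compound 3 to compound 4 expected to show no readable change. The estimate for compound 4 in this assay is 8000 nM, ranging from 2500 nM to 40000 nM.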

Compound 4, half-maximal inhibitory concentration: 1300 nM
Beside the measured number, compound 4's estimate is 6.2-fold (0.79 log units) above it, and the stated range ends above it.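

In this assay, ethyl in place of 1,1-difluoroethyl, on a saturated chain carbon three bonds along the chain from a saturated ring carbon, gives the first readable change: an at least 3.0-fold lower number from compound 3 to compound 4 (0.48 log units; beyond the scatter). Propyl in place of methylsulfonyl, on a saturated chain carbon two bonds along the chain from a saturated ring carbon, likewise gives an at least 3.0-fold lower number from compound 1 to compound 4 (0.48 log units; beyond the scatter). Compound 4 is the only compound shown whose value is not a limit: the limit of > 4000 nM in this assay, at which 3 of the 4 values shown sit.

On these data alone, what a longer chain, or a carboxylic acid in place of the ethyl, would give in this assay stays open.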